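From a Pyrimidinylmethyl Amide to a Methylpyrazolyl Amide

A few compounds are considered here, and "the series" means these few. Any claim that something is new, unique, unknown or untested is made for them only; others in the source may bear on it.

In an ADME assay on microsomes from liver (Mus musculus, strain CD-1) for metabolic stability, read by LC-MS, tested at 2 uM (a lower number here means that the compound disappears faster, a higher number that the compound lasts longer), compound 1 `CNC(=O)c1ccncc1Nc1cc(-c2ccc3ccn(C)c3c2)c2nccnc2c1` gives 0.45 h and compound 2 `Cn1ccc2ccc(-c3cc(Nc4cnccc4C(=O)NCc4cncnc4)cc4nccnc34)cc21` gives 0.4 h. For the measured compounds named here, these two values lie within the scatter of each other, so compound 2 stands level with the only other compound measured so far.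

Compound 3 `Cn1cc(NC(=O)c2ccncc2Nc2cc(-c3ccc4ccn(C)c4c3)c3nccnc3c2)cn1` keeps the shared core and differs from compound 2 at one place: 1-methyl-1H-pyrazol-4-yl in place of (pyrimidin-5-yl)methyl on an amide-type nitrogen. In words, 1-methyl-1H-pyrazol-4-yl takes the place of (pyrimidin-5-yl)methyl on an amide-type nitrogen.

Going by the values given here, only one measured step bears on this change. Placing pyrimidin-5-yl on the saturated chain carbon gave a 1.1-fold lower number from compound 1 to compound 2 (0.05 log units; within the scatter), which is within the scatter. Among the compounds with values here, that step concerns the same amide-type nitrogen, but no measured compound has 1-methyl-1H-pyrazol-4-yl there, so the evidence is thin and the direction of any change is unknown. The expected result in this assay is therefore no step beyond the scatter, and the estimate is no change at the digits printed from compound 2 to compound 3 (within the scatter).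

Compound 3 is expected to show a half-life of about 0.4 h, with an estimated range from 0.2 h to 0.9 h.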

Compound 3, half-life: 0.2 h
Estimate against measurement, compound 3: 2.0-fold (0.30 log units) above, and the stated range covers the measured number.
By their numbers in this assay, from the lowest: compounds 3, 2 and 1 (each within the scatter of the next, the first and the last beyond it).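

In this assay, putting 1-methyl-1H-pyrazol-4-yl in place of (pyrimidin-5-yl)methyl on the amide-type nitrogen gives a 2.0-fold lower number from compound 2 to compound 3 (0.30 log units; within the scatter), so this exchange on its own cannot be told apart from the ordinary spread of repeated measurements. Measured against the small methyl group on the same nitrogen, 1-methyl-1H-pyrazol-4-yl gives a 2.3-fold lower number from compound 1 to compound 3 (0.35 log units; beyond the scatter), a modest step, and the first here to clear the scatter, which shows that the group on this nitrogen can shift the half-life, something the earlier step did not show. Nothing available explains why this group is linked to a shift in half-life.

The exchange from compound 2 to compound 3 alters both the aromatic ring and the saturated chain carbon that joins it to the nitrogen, so the compounds shown cannot separate the contribution of the ring from that of the chain carbon. From the compounds shown here alone, how a (1-methyl-1H-pyrazol-4-yl)methyl group or a plain phenyl group on the same nitrogen would behave remains open.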